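The source may report more compounds than this note shows. Statements on the series, on what has been measured and on what is new or still open speak of the compounds shown alone.

Measured so far:
Compound 1 `O=C1/C(=C/c2ccccc2Br)Cc2ccccc21` gives 64200 nM in a functional assay on L1210 cells (Mus musculus) for inhibition; on this read-out higher numbers stand for weaker inhibition and lower numbers for stronger inhibition.
Compound 2 `O=C1/C(=C/c2ccccc2[N+](=O)[O-])CCc2ccccc21` gives 10800 nM in this assay.

Of these two numbers, compound 1 stands highest; compound 2 is the nearer one, and the gap between them lies beyond the usual scatter. Compound 3 `O=C1/C(=C/c2ccccc2F)Cc2ccccc21` differs from compound 1 by fluoro in place of bromo on an aromatic carbon. Among the measured compounds shown here, no pair of measured compounds shows this change, so nothing measured tells its direction. In this assay the expected step is small, a 1.2-fold higher number from compound 1 to compound 3 (0.10 log units; within the scatter), within the scatter and with no firm direction. Compound 3 is therefore estimated at 80000 nM, with a range from 25000 nM to 250000 nM.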

Compound 3, half-maximal inhibitory concentration: 150000 nM
Estimate against measurement, compound 3: 1.9-fold (0.27 log units) below; the range from low to high includes it.
By their numbers in this assay, from the lowest: compound 2; then compound 1; then compound 3.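

In this assay, fluoro in place of bromo on this aromatic carbon, ortho to a large group, gives a 2.3-fold higher number from compound 1 to compound 3 (0.37 log units; beyond the scatter) and thus weaker inhibition. Among the compounds shown here, this is the first step read at this position, and it shows that the exchange of one halogen for the other is not silent here, though the step is only modest. Nothing at hand accounts for this step.

Open, going by these compounds, is how chloro, a methoxy group or an amine would fare on the same carbon. Also open, on these data alone, is whether fluoro in place of bromo would move the number the same way on the core of compound 2.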